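The compounds below may be only part of what the source reports. "The series", "measured", "known", "first", "only" and "open" are said of these compounds alone.

Measured so far in an ADME assay on Raji cells (Homo sapiens) for cytotoxicity, read by CellTiter-Glo, with a stated time of 72 h; on this read-out higher numbers stand for an effect only at larger amounts of compound and lower numbers for an effect already at smaller amounts:
- compound 1 `CC(=O)O[C@H]1/C=C/C(C)(C)CC2=C(C)C(=O)[C@]3(C[C@@H](C)C=C3/C=C\1C)O2` gives 26000 nM in the first run of the series
- compound 2 `CC1=C2CC(C)(C)/C=C/[C@@H](O)/C(C)=C\C3=C[C@H](C)C[C@]3(O2)C1=O` gives 26000 nM in the same test

Compound 2 stands level with compound 1, the two values lying within the usual scatter of each other. Going by the values given here, compound 3 `CC(=O)O[C@@H]1/C=C/C(C)(C)CC2=C(C)C(=O)[C@]3(C[C@@H](C)C=C3/C=C\1C)O2` has no measurement yet. The change from compound 2 to compound 3 is acetyl in place of hydrogen on an oxygen on a saturated carbon (acetyl in place of hydrogen on an oxygen on a saturated carbon, or hydroxy to acetoxy). Among the compounds with values here, no step between measured compounds is available to size this change. Within the data shown here, the only guide is that compound 1 at 26000 nM and compound 2 at 26000 nM show no gap, so no step beyond the scatter is expected in this assay here. The expected step is a 1.2-fold lower number from compound 2 to compound 3 (0.07 log units; within the scatter) and stays within the scatter. For compound 3 the estimate is 22000 nM with an expected range from 7000 nM to 60000 nM on repeated measurement.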

Compound 3, half-maximal effective concentration: 26000 nM
Compound 3: middle estimate off by 1.2-fold (0.07 log units), on the low side; the measured number falls inside the stated range.
By their numbers in this assay, from the lowest: compounds 1, 2 and 3 (each within the scatter of the next).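

In this assay, acetyl in place of hydrogen on an oxygen on a saturated carbon gives no change at the digits printed from compound 2 to compound 3 (within the scatter), so hydroxy to acetoxy now stands as a measured step in this series rather than an estimate. A stereocentre at a saturated ring carbon, drawn S in one compound and R in the other, gives no change at the digits printed from compound 1 to compound 3 (within the scatter), so this read-out does not separate the two drawn configurations of the acetate. That second comparison isolates configuration alone: the fact that compounds 1 and 3 differ only in the configuration as drawn.

As far as these compounds go, what a longer chain such as butanoyl, or a benzoyl group, would give in place of the acetyl in this assay remains open. Also open, from the compounds shown here alone, is whether an amine or a carboxylic acid carried on this oxygen would give a step beyond the scatter.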